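Methyl on the Chain: Cytotoxicity Outlook for Compound 4

The source may hold more compounds than are shown below. What is called first, only, known or untested is meant among the compounds shown, and "the series" means these compounds.

Compound 1 `O=C(CCSc1nnc(-c2ccncc2)s1)Nc1ccccc1` was tested in an ADME assay on HepG2 cells (Homo sapiens) for cytotoxicity, with a stated time of 3 days; on this read-out lower numbers stand for higher toxicity in this test and higher numbers for lower toxicity in this test. In this assay compound 1 gives > 50000 nM, which is a limit of the assay rather than a number. Compound 2 `O=C(CCSc1nnc(-c2ccncc2)s1)Nc1ccc(Cl)cc1Cl` gives > 50000 nM in this assay, also a limit. Compound 3 `O=C(CCSc1nnc(-c2ccncc2)s1)Nc1ccccc1Cl` gives > 50000 nM in this assay, again a limit. Because all three sit at the limit of > 50000 nM in this assay, at which 3 of the 3 values shown sit, the steps a step that the two limits leave unreadable from compound 1 to compound 2 and a step that the two limits leave unreadable from compound 1 to compound 3 cannot be sized. Compound 4 `CC(CSc1nnc(-c2ccncc2)s1)C(=O)Nc1ccccc1` differs from compound 1 by methyl in place of hydrogen on a saturated chain carbon bound to a carbonyl carbon and a saturated chain carbon. Among the measured compounds shown here, no measured step matches this change; the measured ones, adding chloro or swapping phenyl for 2,4-dichlorophenyl, never brought toxicity into view. Compound 4 is therefore expected to remain at the limit, with an estimated 50000 nM (range 25000 nM to 100000 nM). The expected step of a number no higher from compound 1 to compound 4 (the limit leaves the size open) is nil beyond the scatter.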

Compound 4, half-maximal cytotoxic concentration: > 50000 nM
Compound 4: a limit, no number (the forecaster's own chance of this, stated with the estimate: 85%); the middle value lies on the limit itself.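

Among the compounds shown here, compound 1 and compound 4 both give only a limit, so no step between them can be read: the limit of > 50000 nM in this assay, at which 4 of the 4 values shown sit. Going by these compounds, whether methyl in place of hydrogen changes toxicity in this test stays open, as does any ranking of the four compounds.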